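Removing trifluoromethyl from a limit-bound azo compound

The source may hold more compounds than are shown below. What is called first, only, known or untested is meant among the compounds shown, and "the series" means these compounds.

Compound 1 `Clc1cccc(/N=N/N2CCCC2)c1` gives > 100000 nM (a limit)
Compound 2 `Cc1c(/N=N/c2cccc(C(F)(F)F)c2)ccc(NC[C@@H]2CCCN3CCCC[C@H]23)c1C` gives >= 100000 nM (a limit)
Compound 3 `Fc1ccc(/N=N/c2ccc(NC[C@@H]3CCCN4CCCC[C@H]34)c3c2CCCC3)c(F)c1` gives 9000 nM (a number)

In an ADME assay on BHK-21 cells (Mesocricetus auratus) for cytotoxicity, read by MTT assay, with a stated time of 96 h (on this read-out higher numbers stand for lower toxicity in this test and lower numbers for higher toxicity in this test), compound 2 gives >= 100000 nM, and this is a limit of the test, not a number. Compound 1 also stands at a limit, so compound 3 alone offers a true number. Compound 4 `Cc1c(/N=N/c2ccccc2)ccc(NC[C@@H]2CCCN3CCCC[C@H]23)c1C` follows from compound 2 by one change (hydrogen in place of trifluoromethyl on an aromatic carbon), with hydrogen in place of trifluoromethyl on an aromatic carbon, meta to a large group, so that 3-(trifluoromethyl)phenyl becomes phenyl. Within the data shown here, no measured pair in this set shows what such a change does. Compound 3 gives 9000 nM in this assay, which shows that lower numbers can occur among these compounds. A moderate step toward a lower number is therefore expected, though none beyond the scatter remains possible. The estimated step is an at least 2.0-fold lower number from compound 2 to compound 4 (0.30 log units; that floor lies within the scatter) (an expectation only). Compound 4 is expected at 50000 nM (estimated range 12000 nM to 100000 nM).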

Compound 4, half-maximal cytotoxic concentration: 47000 nM
Compound 4: the middle estimate sits 1.1-fold (0.03 log units) above what was measured; the range from low to high includes it.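

In this assay, among these compounds, hydrogen in place of trifluoromethyl on an aromatic carbon, meta to a large group, gives an at least 2.1-fold lower number from compound 2 to compound 4 (0.32 log units; beyond the scatter) and is the only change in this set that can be read as a measured pair. It shows that this place is not indifferent to the exchange: the loss of trifluoromethyl takes the series from a limit to a true number, on the side of higher toxicity in this test. The size of the step remains a floor, because compound 2 stands at a limit and not at a number: the limit of >= 100000 nM in this assay, at which 1 of the 4 values shown sits.

The compounds shown leave open whether a fluorine, a methoxy group, an amine or a carboxylic acid at this place would give a number close to that of compound 4. They also leave open whether the same exchange on another core would give a step of similar size.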